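The source may report more compounds than this note shows. Statements on the series, on what has been measured and on what is new or still open speak of the compounds shown alone.

Going by the values given here, in a functional assay on A549 cells (Homo sapiens) for antiproliferative activity, with a stated time of 5 days (a lower number here means a stronger inhibitor, a higher number a weaker inhibitor), compound 1 (`COc1ccc(-n2nc(-c3ccc4ccccc4c3)nc2N2C(=O)COC23C=CC(=O)C=C3)cc1`) gives 260 nM, the lower of the two numbers measured so far, and compound 2 (`COc1ccc(-n2nc(-c3ccc4ccccc4c3)nc2N2C(=O)C(C)OC23C=CC(=O)C=C3)cc1`) gives 860 nM. Compound 3 (`O=C1C=CC2(C=C1)OCC(=O)N2c1nc(-c2ccc3ccccc3c2)nn1-c1ccc(Cl)cc1`) differs from compound 1 by chloro in place of methoxy on an aromatic carbon. Among the compounds with values here, the only measured step, a 3.3-fold higher number from compound 1 to compound 2 (0.52 log units; beyond the scatter), is methyl in place of hydrogen on a saturated ring carbon, so it is a modest step at a different place and does not test this change. No step beyond the scatter is therefore expected in this assay. Compound 3 is expected at 300 nM, estimated between 100 nM and 900 nM, an expected 1.2-fold higher number from compound 1 to compound 3 (0.06 log units; within the scatter).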

Compound 3, half-maximal inhibitory concentration: 400 nM
Compound 3: the middle estimate sits 1.3-fold (0.12 log units) below what was measured; the measured number falls inside the stated range.
By their numbers in this assay, from the lowest: compounds 1 and 3 (each within the scatter of the next); then compound 2.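

Replacing 4-methoxyphenyl with 4-chlorophenyl in this assay gives a 1.5-fold higher number from compound 1 to compound 3 (0.19 log units; within the scatter), so at this position, para to a large group, chloro can stand in place of methoxy with no step beyond the scatter. This is the first change at this position among the compounds shown, since the step to compound 2 lay on a saturated ring carbon. No measurement explains the result.

From the compounds shown here alone, whether an amine, a carboxylic acid or a longer chain such as butoxy would be accommodated at this position remains open. So does whether the same change would behave alike on compound 2.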